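A few compounds are considered here, and "the series" means these few. Any claim that something is new, unique, unknown or untested is made for them only; others in the source may bear on it.

Measured compounds:
compound 1, `Cc1cc(C)c(CN2CCc3c(Cl)cc([C@@H](CO)[C@@H]4CCOC4)c(Cl)c3C2=O)c(=O)[nH]1`: 2910 nM
compound 2, `Cc1cc(C)c(CN2CCc3c(Cl)cc(-c4c(C)noc4C)c(Cl)c3C2=O)c(=O)[nH]1`: 17 nM

In an assay on cells for inhibition of histone-lysine N-methyltransferase EZH2 (Homo sapiens), read by ELISA, with a stated time of 72 h (on this read-out lower numbers stand for stronger inhibition and higher numbers for weaker inhibition), compound 2 gives 17 nM, the lowest of the two numbers. Going by the values given here, its only neighbour is compound 1, which in this assay gives 2910 nM, and the two are separated by a 170-fold lower number from compound 1 to compound 2 (2.23 log units; beyond the scatter), a large step well beyond the scatter.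

Compound 3, `Cc1cc(C)c(CN2CCc3c(Cl)cc([C@H](CO)[C@@H]4CCCO4)c(Cl)c3C2=O)c(=O)[nH]1`, has not yet been measured. It differs from compound 2 in a single place: a group of 8 heavy atoms (6 carbon, 2 oxygen; one five-membered non-aromatic ring with 1 hetero atom) in place of a group of 7 heavy atoms (5 carbon, 1 nitrogen, 1 oxygen; one five-membered aromatic ring with 2 hetero atoms), on an aromatic carbon. Among the compounds with values here, the entering group closely resembles the one carried by compound 1, a five-membered non-aromatic ring with one hetero atom bearing a hydroxymethyl chain, so the change largely undoes the one measured step. That step, a 170-fold lower number from compound 1 to compound 2 (2.23 log units; beyond the scatter), is the only one that bears on the question, and it points toward a large upward movement in this assay when the 3,5-dimethyl-1,2-oxazol-4-yl group is given up. A step of roughly a 120-fold higher number from compound 2 to compound 3 (2.07 log units; beyond the scatter) is therefore expected for compound 3. Compound 3 is estimated to give about 2000 nM in this assay, most likely between 500 nM and 7000 nM.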

Compound 3, half-maximal inhibitory concentration: 41 nM
Estimate against measurement, compound 3: 49-fold (1.69 log units) above; the whole stated range lies above it.
By their numbers in this assay, from the lowest: compound 2; then compound 3; then compound 1.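

In this assay, this aromatic carbon, ortho to a chloro group, proves able to carry a non-aromatic group with little loss: a 2.4-fold higher number from compound 2 to compound 3 (0.38 log units; beyond the scatter) is modest, so the 3,5-dimethyl-1,2-oxazol-4-yl group is not required for a low number, although compound 2 remains the lowest of the three. The a 71-fold lower number from compound 1 to compound 3 (1.85 log units; beyond the scatter) shows how finely this position discriminates, since the two groups have the same heavy-atom count and each has a five-membered non-aromatic ring with one hetero atom, yet they differ in where the ring oxygen stands and in the arrangement of their defined stereocentres. The large loss seen earlier with compound 1 therefore cannot be read as the general cost of replacing the aromatic ring with a non-aromatic one.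

Nothing given here accounts for these differences. The compounds leave open whether the ring-oxygen location or the stereocentres drive the gap between compound 1 and compound 3, and whether an amine or a longer chain in place of the hydroxymethyl group would keep the number low.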